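Replacing the ring substituent of compound 2 with an open chain

This account rests on a few compounds, and the source may have more. Where it says the series, first, only, none or still open, it means among the compounds named here.

- compound 1 `CN(C)CCCCCn1c2c(c3ccccc31)C(=O)c1c[n+]([O-])c3ccccc3c1C2=O`: 210 nM
- compound 2 `O=C1c2c[n+]([O-])c3ccccc3c2C(=O)c2c1c1ccccc1n2Cc1cn([C@@H]2C[C@H](O)[C@@H](CO)O2)nn1`: 120 nM

Both values come from a functional assay on A549 cells (Homo sapiens) for cytotoxicity, read by MTT assay, with a stated time of 72 h; a higher number here means a weaker inhibitor, a lower number a stronger inhibitor. Compound 2 gives 120 nM, which lies within the scatter of compound 1 at 210 nM, so the two cannot be ranked. Compound 3 `O=C1c2c[n+]([O-])c3ccccc3c2C(=O)c2c1c1ccccc1n2Cc1cn(C[C@H](O)CO)nn1` has not yet been measured. It keeps the core of compound 2 and has 2,3-dihydroxypropyl in place of 4-hydroxy-5-(hydroxymethyl)oxolan-2-yl on an aromatic nitrogen. Among the measured compounds shown here, no measured pair differs in one place, so no direct precedent exists for this change. The side chains of compound 1 and compound 2 differ widely, yet their values stay within the scatter, which suggests a modest effect here. The expected result is a 1.3-fold higher number from compound 2 to compound 3 (0.12 log units; within the scatter), a slightly higher number that is not clearly beyond the scatter. For compound 3 the estimated value is 160 nM, with an expected range of 60 nM to 420 nM.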

Compound 3, half-maximal inhibitory concentration: 1030 nM
The estimate for compound 3 lay 6.4-fold (0.81 log units) below the measured number; the whole stated range lies below it.
By their numbers in this assay, from the lowest: compounds 2 and 1 (each within the scatter of the next); then compound 3.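

In this assay, opening the 4-hydroxy-5-(hydroxymethyl)oxolan-2-yl ring to 2,3-dihydroxypropyl on the aromatic nitrogen gives an 8.6-fold higher number from compound 2 to compound 3 (0.93 log units; beyond the scatter), so this position is sensitive to the group it carries, which the values of compounds 1 and 2 alone did not reveal. The side chain of compound 3 also compares poorly with the 4-(dimethylamino)butyl chain, with a 4.9-fold higher number from compound 1 to compound 3 (0.69 log units; beyond the scatter), so an open chain is not disfavoured as such and the diol-bearing chain is what falls short here. No measurement shown explains the step.

From the compounds shown here alone, it remains open whether the ring itself or its particular hydroxyl groups carry the difference. A plain oxolan-2-yl ring, a longer diol chain or an amine at this nitrogen would help separate these possibilities.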